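Removing one chloro group: notes on the series

The compounds below may be only part of what the source reports. "The series", "measured", "known", "first", "only" and "open" are said of these compounds alone.

Compound 1 `CC(=O)n1nc(C)c(-c2ccc(Cl)c(Cl)c2)c1N`, compound 2 `Cc1nn(C(=O)C2CC2)c(N)c1-c1ccc(Cl)c(Cl)c1` and compound 3 `Cc1nn(C(=O)C2CC2)c(N)c1-c1ccc(Cl)cc1` share a core and have been measured in an assay on Sf9 cells for inhibition of mitogen-activated protein kinase kinase kinase 14 (Homo sapiens), read by ADP-Glo, with a stated time of 60 min; a lower number here means a stronger inhibitor, a higher number a weaker inhibitor. Compound 1 gives 8400 nM and compound 2 gives 24300 nM. For compound 3 the value > 100000 nM is a limit in this assay, not a number. The cores of compound 1 and compound 2 differ by methyl in place of cyclopropyl on a carbonyl carbon, giving a 2.9-fold higher number from compound 1 to compound 2 (0.46 log units; beyond the scatter). The step of an at least 4.1-fold higher number from compound 2 to compound 3 (0.61 log units; beyond the scatter) comes from hydrogen in place of chloro on an aromatic carbon; one of the three values sits at the limit of > 100000 nM in this assay, at which 1 of the 3 values shown sits. Compound 4 `CC(=O)n1nc(C)c(-c2cccc(Cl)c2)c1N` is not yet measured and differs from compound 1 by hydrogen in place of chloro on an aromatic carbon. This is the same kind of change as from compound 2 to compound 3, though the place there is meta to a large group and here para to a large group. Resting on an at least 4.1-fold higher number from compound 2 to compound 3 (0.61 log units; beyond the scatter), the expected step here is a 4.8-fold higher number from compound 1 to compound 4 (0.68 log units; beyond the scatter). Compound 4 is estimated at 40000 nM, between 15000 nM and 150000 nM.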

Compound 4, half-maximal inhibitory concentration: > 100000 nM
Compound 4 ended at the assay's limit (the forecaster's own chance of this, stated with the estimate: 30%); middle value at least 2.5-fold (0.39 log units) from the limit.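

In this assay the change again gives a weaker compound, with an at least 11-fold higher number from compound 1 to compound 4 (1.07 log units; beyond the scatter). Compound 4 gives > 100000 nM, which is a limit of the assay and not a number. The direction of the change therefore carries from one core to the other, but its size does not transfer in any readable way, and the chloro group removed is not in the same place on the two cores: the same change on two cores in this assay, an at least 4.1-fold higher number (0.61 log units; beyond the scatter) from compound 2 to compound 3 and an at least 11-fold higher number (1.07 log units; beyond the scatter) from compound 1 to compound 4; the limit leaves it open whether they differ

Still open, going by these compounds, is whether a fluoro, methyl or methoxy group in place of either chloro group would retain the value of compound 1. Also open, on these data alone, is how a longer chain on the carbonyl carbon, such as ethyl or propyl, would compare with methyl and cyclopropyl.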